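A few compounds are considered here, and "the series" means these few. Any claim that something is new, unique, unknown or untested is made for them only; others in the source may bear on it.

Among the measured compounds shown here, compound 2 `COc1ccc(C(=O)Nc2c(C(O)(C(F)(F)F)C(F)(F)F)ccc3ccccc23)cc1` gives 417 nM in an assay on LtK cells with ATP-sensitive inward rectifier potassium channel 11 (Homo sapiens) as the target (on this read-out higher numbers stand for an effect only at larger amounts of compound and lower numbers for an effect already at smaller amounts), the highest of the two numbers measured so far, while compound 1 `CCCC(=O)Nc1c(C(O)(C(F)(F)F)C(F)(F)F)ccc2ccccc12` gives 131 nM there. For the measured compounds named here, the one step measured, a 3.2-fold higher number from compound 1 to compound 2 (0.50 log units; beyond the scatter), swaps a chain for an aromatic ring rather than one ring for another, so it bears only loosely on the change to compound 3 `O=C(Nc1c(C(O)(C(F)(F)F)C(F)(F)F)ccc2ccccc12)c1ccc(Cl)c(Cl)c1`, which is 3,4-dichlorophenyl in place of 4-methoxyphenyl on a carbonyl carbon. Going by the values given here, with no measured step between two aromatic rings on this carbonyl carbon, the expectation for a 1.4-fold lower number from compound 2 to compound 3 (0.14 log units; within the scatter) is a step hardly beyond the scatter, and compound 3 is estimated at 300 nM, within 100 nM to 900 nM.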

Compound 3, half-maximal effective concentration: 194 nM
Estimate against measurement, compound 3: 1.5-fold (0.19 log units) above; the measured number falls inside the stated range.
By their numbers in this assay, from the lowest: compounds 1 and 3 (each within the scatter of the next); then compound 2.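

On this carbonyl carbon two aromatic rings can now be compared directly: 3,4-dichlorophenyl in place of 4-methoxyphenyl gives a 2.1-fold lower number from compound 2 to compound 3 (0.33 log units; beyond the scatter). The earlier step away from propyl therefore does not hold for every aromatic ring, since 3,4-dichlorophenyl in place of propyl gives a 1.5-fold higher number from compound 1 to compound 3 (0.17 log units; within the scatter), so which ring is attached matters here. Nothing measured here accounts for the difference between the two rings.

The compounds shown leave open how a phenyl ring carrying a single chlorine, an amine or a carboxylic acid would read at this place. They also leave open how a chain longer than propyl would read.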